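Epimer of compound 3: expected cytotoxicity in the series

A few compounds are considered here, and "the series" means these few. Any claim that something is new, unique, unknown or untested is made for them only; others in the source may bear on it.

Notes on a small set of camphor-derived amino alcohols. Compound 1 `CC1(C)[C@@H]2CC[C@@]1([C@@H](O)CN1CCN(c3ccc(Cl)cc3)CC1)C(=O)C2` and compound 3 `CC1(C)[C@@H]2CC[C@@]1([C@H](O)CN1CCN(c3ccc(F)cc3)CC1)C(=O)C2` carry an arylpiperazine on the hydroxyethyl chain; compound 2 `CN1CCN(C[C@H](O)[C@]23CC[C@H](CC2=O)C3(C)C)CC1` carries a methylpiperazine instead. In an ADME assay on HEK-293T cells (Homo sapiens) for cytotoxicity, read by MTT assay, with a stated time of 72 h (a lower number here means a stronger inhibitor, a higher number a weaker inhibitor), compound 1 gives 8600 nM. In this assay compound 3 gives 65100 nM, the highest number of the two reported, with compound 1 the nearest at a clearly lower number. For compound 2 this assay gives "not determined" (no result reported), so no number exists for it. Within the data shown here, no pair among the measured compounds differs in only one place, so no single step is defined within the set.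

Compound 4 `CC1(C)[C@@H]2CC[C@@]1([C@@H](O)CN1CCN(c3ccc(F)cc3)CC1)C(=O)C2` is not yet measured in this assay. Compound 4 differs from compound 3 as follows: the two compounds have the same atoms and bonds and differ only in configuration as drawn: 1 of 3 stereo elements differ; a stereocentre at a saturated chain carbon is drawn S in compound 3 and R in compound 4. Among the measured compounds shown here, because no measured pair isolates a change of configuration in this assay, the size of this step cannot be read from the numbers; a step of moderate size is expected, with the number for compound 4 coming out lower than that of compound 3, but the step from compound 3 to compound 4 is expected to be a 2.6-fold lower number from compound 3 to compound 4 (0.42 log units; beyond the scatter) and could also fall within the scatter. Compound 4 is expected to give 25000 nM, with a range from 7000 nM to 90000 nM.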

Compound 4, half-maximal inhibitory concentration: 82200 nM
For compound 4 the middle estimate is 3.3-fold (0.52 log units) below the measured one; the measured number falls inside the stated range.
By their numbers in this assay, from the lowest: compound 1; then compounds 3 and 4 (each within the scatter of the next).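

In this assay, among these compounds, a 1.3-fold higher number from compound 3 to compound 4 (0.10 log units; within the scatter) gives the first reading of this stereocentre at a saturated chain carbon, and drawing it S or R makes no difference that can be told from the scatter in the fluoro series. This step isolates configuration and nothing else, so the result can be tied to this stereocentre alone: the fact that compounds 3 and 4 differ only in the configuration as drawn In the same assay, this assay also yields the first single-place step on the aromatic ring substituent, a 9.6-fold higher number from compound 1 to compound 4 (0.98 log units; beyond the scatter), which lies beyond the scatter and makes fluoro in place of chloro on an aromatic carbon the only change shown here to move the number, while the change of configuration does not.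

Whether the stereocentre stays equally silent with chloro on the aromatic carbon remains open, as only one configuration of the chloro compound appears among the compounds shown. Also open, from the compounds shown here alone, is where a bromo, methoxy or nitrile group at the same aromatic carbon would fall relative to the fluoro and chloro compounds.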